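Extending the ring nitrogen of compound 3 with a hexyl chain

The source may report more compounds than this note shows. Statements on the series, on what has been measured and on what is new or still open speak of the compounds shown alone.

Compound 1, `CN1CCN(c2nc3ccccc3n2CCO)CC1`: 410 nM in a functional assay on ileum for inhibition of histamine H1 receptor (Cavia porcellus); a higher number here means a weaker inhibitor, a lower number a stronger inhibitor.
Compound 2, `CCCCN1CCCN(c2nc3ccccc3n2CCOCC)CC1`: 8.4 nM in this assay.
Compound 3, `CN1CCN(c2nc3ccccc3[nH]2)CC1`: > 3000 nM in this assay, which is a limit of the assay and not a number.

Compound 3 therefore stands at the weak end of what has been measured so far; of the three values shown, it is the one that sits at the limit of > 3000 nM in this assay, at which 1 of the 3 values shown sits. Its nearest measured neighbour is compound 1, which carries a 2-hydroxyethyl group on the aromatic nitrogen of the shared core and gives a number rather than a limit. That single step, hydrogen in place of 2-hydroxyethyl on an aromatic nitrogen, is an at least 7.3-fold higher number from compound 1 to compound 3 (0.86 log units; beyond the scatter).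

Compound 4, `CCCCCCn1c(N2CCN(C)CC2)nc2ccccc21`, has not yet been measured. It differs from compound 3 in one place: hexyl in place of hydrogen on an aromatic nitrogen. Within the data shown here, the only measured step that bears on this change is the one from compound 1 to compound 3, which shows that a bare hydrogen on that nitrogen goes with the weakest result, while a two-carbon substituent there gives a clearly lower number. Compound 2 also carries a substituent on that nitrogen and gives the lowest number of the set, but it differs from compound 3 in more than one place, so only its value can be noted.

On that basis the hexyl substituent is expected to move compound 4 in the direction of a lower number in this assay, by a step of roughly an at least 20-fold lower number from compound 3 to compound 4 (1.30 log units; beyond the scatter). Compound 4 is accordingly estimated at 150 nM, within a range of 30 nM to 1000 nM.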

Compound 4, half-maximal inhibitory concentration: 26 nM
Compound 4: middle estimate off by 5.8-fold (0.76 log units), on the high side; measured number below the stated range.
By their numbers in this assay, from the lowest: compound 2; then compound 4; then compound 1. At a limit, above all of these: compound 3.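

The earlier compounds shown here showed a measured number on this aromatic nitrogen only with 2-hydroxyethyl, and compound 4 shows that a hexyl chain, which carries no hydrogen-bond donors or acceptors, also goes with a far lower number in this assay: an at least 110-fold lower number from compound 3 to compound 4 (2.06 log units; beyond the scatter). Set against the 2-hydroxyethyl group, the hexyl chain goes further still, with a 16-fold lower number from compound 1 to compound 4 (1.20 log units; beyond the scatter), so at this position the hydroxy group is not needed for a low number among the compounds shown. The first of these steps has only one measured end, since compound 3 stands at a limit of the assay and not at a number: the limit of > 3000 nM in this assay, at which 1 of the 4 values shown sits.

On these data alone, whether the number keeps falling with a chain longer than hexyl, or holds up with an amine or a carboxylic acid at the end of the chain, stays open. Compound 2, at 8.4 nM, differs from compound 4 in more than one place, so the part played by its ethoxyethyl chain on this nitrogen cannot be read from these compounds.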